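Phosphate ester variation on a fluorinated nucleoside scaffold

A few compounds are considered here, and "the series" means these few. Any claim that something is new, unique, unknown or untested is made for them only; others in the source may bear on it.

Measured compounds:
Compound 1, `O=C(O[C@H]1C[C@H](n2cc(F)c(=O)[nH]c2=O)O[C@@H]1COP(=O)(O)Oc1cccnc1)c1ccccc1`, 6900 nM
Compound 2, `C[n+]1cccc(OP(=O)([O-])OC[C@H]2O[C@@H](n3cc(F)c(=O)[nH]c3=O)C[C@@H]2OC(=O)c2ccccc2)c1`, 1260 nM
Compound 3, `CCOC(=O)C[n+]1cccc(OP(=O)([O-])OC[C@H]2O[C@@H](n3cc(F)c(=O)[nH]c3=O)C[C@@H]2OC(=O)c2ccccc2)c1`, 6100 nM

In a functional assay on HeLa cells (Homo sapiens) for cytotoxicity, read by MTT assay, with a stated time of 48 h (on this read-out higher numbers stand for weaker inhibition and lower numbers for stronger inhibition), compound 3 stands second highest of the three numbers; its nearest neighbour is compound 1, within the scatter, and its furthest is compound 2, beyond the scatter. Two measured steps frame the series: a 5.5-fold lower number from compound 1 to compound 2 (0.74 log units; beyond the scatter), and then a 4.8-fold higher number from compound 2 to compound 3 (0.68 log units; beyond the scatter), so that the charged, methyl-bearing compound 2 gives the lowest number of the three.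

Compound 4, `C[N+]1(C)CCC(OP(=O)([O-])OC[C@H]2O[C@@H](n3cc(F)c(=O)[nH]c3=O)C[C@@H]2OC(=O)c2ccccc2)CC1`, differs from compound 3 by a group of 8 heavy atoms (7 carbon, 1 nitrogen; one six-membered non-aromatic ring with 1 hetero atom) in place of a group of 12 heavy atoms (9 carbon, 1 nitrogen, 2 oxygen; one six-membered aromatic ring with 1 hetero atom), on an oxygen. The new group, like that of compound 2, carries a methylated nitrogen with a net positive charge and no ethoxycarbonyl. For the measured compounds named here, because a 4.8-fold higher number from compound 2 to compound 3 (0.68 log units; beyond the scatter) shows the ethoxycarbonyl accompanying a higher number, its absence in compound 4 points toward a lower number in this assay, though the ring entering is non-aromatic and has no measured counterpart here, which widens the uncertainty. Compound 4 is therefore expected to show a 2.4-fold lower number from compound 3 to compound 4 (0.39 log units; beyond the scatter), and its value is estimated at 2500 nM, with a range from 900 nM to 7000 nM.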

Compound 4, half-maximal inhibitory concentration: 27200 nM
Beside the measured number, compound 4's estimate is 11-fold (1.04 log units) below it, outside the stated range (above it).
By their numbers in this assay, from the lowest: compound 2; then compounds 3 and 1 (each within the scatter of the next); then compound 4.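

The non-aromatic ring with its doubly methylated nitrogen gives the highest number of the series in this assay, with a 4.5-fold higher number from compound 3 to compound 4 (0.65 log units; beyond the scatter) and, against the closest comparison, a 22-fold higher number from compound 2 to compound 4 (1.33 log units; beyond the scatter). It also falls behind compound 1, with a 3.9-fold higher number from compound 1 to compound 4 (0.60 log units; beyond the scatter), so a methylated nitrogen with a net positive charge does not by itself go with a low number: compound 2 has one and gives the lowest number, while compound 4 has one and gives the highest. Nothing available here explains this change.

The compounds shown leave open whether the higher number follows the loss of the aromatic ring or the second methyl on the nitrogen. A secondary amine or a singly methylated tertiary amine in the same non-aromatic ring would separate the two.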